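A few compounds are considered here, and "the series" means these few. Any claim that something is new, unique, unknown or untested is made for them only; others in the source may bear on it.

Measured compounds:
compound 1 `COc1ccc(OC)c(/C=C/c2nnc(Nc3ccc(Cl)cc3)o2)c1`, 3810 nM
compound 2 `COc1ccc(OC)c(/C=C/C(=O)N/N=C/c2ccc(Cl)cc2)c1`, 184 nM

In a functional assay on U-251 cells (Homo sapiens) for antiproliferative activity, read by sulforhodamine B assay, with a stated time of 48 h (a lower number here means a stronger inhibitor of growth, a higher number a weaker inhibitor of growth), compound 2 gives 184 nM, the lowest of the two numbers; compound 1 gives 3810 nM, a gap beyond the scatter. Compound 3 `COc1ccc(OC)c(/C=C/C(=O)N/N=C/c2ccccc2)c1` differs from compound 2 by hydrogen in place of chloro on an aromatic carbon of a six-membered aromatic ring of carbon only. Among the compounds with values here, no measured pair shows this change here. A modest loss of potency, near the edge of the scatter, is expected, so that this assay reports a 2.2-fold higher number from compound 2 to compound 3 (0.34 log units; beyond the scatter) for the step. Compound 3 is estimated at 400 nM, within 150 nM to 1200 nM.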

Compound 3, concentration for 50% growth inhibition: 3680 nM
Beside the measured number, compound 3's estimate is 9.2-fold (0.96 log units) below it, and the stated range ends below it.
By their numbers in this assay, from the lowest: compound 2; then compounds 3 and 1 (each within the scatter of the next).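

Going from 4-chlorophenyl to phenyl gives a 20-fold higher number from compound 2 to compound 3 (1.30 log units; beyond the scatter) in this assay and shows that, in this pair, the low number of compound 2 depends on the chloro on the aromatic ring. Within the data shown here, the earlier compounds offered no pair differing in one place, so this is the first direct reading of this position, and the step is large. Nothing measured here explains its size. As far as these compounds go, whether fluoro, methoxy or an amine at this place would keep the number of compound 2 remains open.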